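The source may report more compounds than this note shows. Statements on the series, on what has been measured and on what is new or still open speak of the compounds shown alone.

Three compounds of the series share one core. Compound 1 `Cc1ccc(-c2n[nH]cc2N2CCCNCC2)cc1`, compound 2 `COc1cccc(-c2n[nH]cc2N2CCNCC2)c1` and compound 3 `Clc1ccccc1-c1n[nH]cc1N1CCNCC1` have been tested in an assay on isolated protein for binding affinity to 5-hydroxytryptamine receptor 4 (Homo sapiens); on this read-out higher numbers stand for weaker inhibition and lower numbers for stronger inhibition. For compound 1 the read-out is only a limit of the assay, > 10000 nM. For compound 2 the read-out is likewise only a limit, > 10000 nM. For compound 3 again only a limit is reported, > 10000 nM. Compound 2 therefore stands at the limit of > 10000 nM in this assay, at which 3 of the 3 values shown sit, and no number is known for it beyond that. Compound 4 `Fc1cccc(-c2n[nH]cc2N2CCNCC2)c1` is not yet measured and differs from compound 2 by fluoro in place of methoxy on an aromatic carbon. Among the measured compounds shown here, since every measured value sits at the limit, no step of any size can be read from the set. The expected step is a step that the limit leaves unreadable from compound 2 to compound 4, none beyond the scatter. Compound 4 is estimated at 15000 nM, within 4000 nM to 60000 nM, most likely again reported only as a limit.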

Compound 4, inhibition constant: > 10000 nM
Compound 4: no number, only a limit; the forecaster's own chance of this, stated with the estimate: 80%; the middle value does not contradict the limit.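

No step from compound 2 to compound 4 can be read, as both are reported only as limits: the limit of > 10000 nM in this assay, at which 4 of the 4 values shown sit.

The compounds shown leave open which change on the shared core, if any, would give a measurable value in this assay.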